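This account rests on a few compounds, and the source may have more. Where it says the series, first, only, none or still open, it means among the compounds named here.

Measured in a functional assay on HOS cells (Homo sapiens) for antiproliferative activity, with a stated time of 72 h; a higher number here means a weaker inhibitor, a lower number a stronger inhibitor:
Compound 1 `OC[C@H]1O[C@@H](n2cnc3c(NCc4ccc(Cl)cc4)ncnc32)[C@H](O)[C@@H]1O`: > 166000 nM
Compound 2 `OC[C@H]1O[C@@H](n2cnc3c(NCc4ccc(Br)cc4)ncnc32)[C@H](O)[C@@H]1O`: > 166000 nM
Compound 3 `Cc1ccc(CNc2ncnc3c2ncn3[C@@H]2O[C@H](CO)[C@@H](O)[C@H]2O)cc1`: > 166000 nM

Each of these entries is a limit of the assay and not a number. Compound 3 has only its limit of > 166000 nM in this assay. It shares that standing with the other two compounds, and the series sits together at the limit of > 166000 nM in this assay, at which 3 of the 3 values shown sit.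

The next compound is compound 4 `OC[C@H]1O[C@@H](n2cnc3c(NCc4ccc(OC(F)(F)F)cc4)ncnc32)[C@H](O)[C@@H]1O`. It is reached by trifluoromethoxy in place of methyl on an aromatic carbon, para to a large group: trifluoromethoxy in place of methyl on an aromatic carbon.

Three measured steps exchange a group on an aromatic carbon and so bear on this change: a step that the two limits leave unreadable from compound 1 to compound 2, a step that the two limits leave unreadable from compound 1 to compound 3 and a step that the two limits leave unreadable from compound 2 to compound 3. None of them has a readable size, so they give no measured effect to carry over. Chloro, bromo and methyl all end at the same limit, however, and on that basis no step beyond the scatter is expected in this assay, in either direction. Compound 4 will most likely be reported as a limit again.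

The estimate means a number no higher from compound 3 to compound 4 (the limit leaves the size open), which is an expected step and not a measured one. For compound 4 the estimated value is 166000 nM, with an expected range from 70000 nM to 250000 nM.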

Compound 4, half-maximal inhibitory concentration: > 166000 nM
Compound 4 gave a limit, no number; the forecaster's own chance of this, stated with the estimate: 85%; the middle value lies on the limit itself.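

In this assay compound 4 gives > 166000 nM, which is a limit and not a number. Among these compounds, no step from compound 1, compound 2 or compound 3 to compound 4 can therefore be read, and all four compounds stand together: the limit of > 166000 nM in this assay, at which 4 of the 4 values shown sit. The compounds shown leave open how strongly any of the four acts in this assay, and whether exchanging the group on the aromatic carbon changes that at all.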